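Working notes: the step from compound 3 to compound 4

The compounds below may be only part of what the source reports. "The series", "measured", "known", "first", "only" and "open" are said of these compounds alone.

Of the compounds shown here, three have been read in a functional assay on MCF7 cells (Homo sapiens) for inhibition, read by MTT assay, with a stated time of 24 h; on this read-out higher numbers stand for weaker inhibition of growth and lower numbers for stronger inhibition of growth. Compound 1 (`COc1ccc(C(=O)n2c(-c3cn(C)c4ccccc34)nc3ccccc32)cc1`) gives 16300 nM, and compound 2 (`COc1ccc(C(=O)n2c(-c3cn(C)c4ccc(OC)cc34)nc3ccccc32)cc1`) gives 14800 nM. Between these two the measured step is a 1.1-fold lower number from compound 1 to compound 2 (0.04 log units; within the scatter), with methoxy in place of hydrogen on an aromatic carbon, and it lies within the scatter. Compound 3 (`COc1ccccc1C(=O)n1c(-c2cn(C)c3ccc(Br)cc23)nc2ccccc21`) gives 36200 nM, the highest of the three numbers and beyond the scatter of the other two.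

Compound 4 (`COc1ccc(C(=O)n2c(-c3cn(C)c4ccc(Br)cc34)nc3ccccc32)cc1`) is not yet measured. It differs from compound 3 as follows: 4-methoxyphenyl in place of 2-methoxyphenyl on a carbonyl carbon. In words, this is 4-methoxyphenyl in place of 2-methoxyphenyl on a carbonyl carbon. For the measured compounds named here, no measured step covers this change directly, and the one available step sits at a different place in the structure. Compound 1 and compound 2 do, however, carry the same 4-methoxyphenyl as compound 4, and their small step of a 1.1-fold lower number from compound 1 to compound 2 (0.04 log units; within the scatter) suggests a number near theirs, though with wide uncertainty. In this assay the expected move is therefore towards a lower number, at about the edge of the scatter. The expected step is a 2.1-fold lower number from compound 3 to compound 4 (0.33 log units; beyond the scatter). For compound 4 the estimate is 17000 nM, with an expected range of 8000 nM to 35000 nM.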

Compound 4, concentration for 50% growth inhibition: 19200 nM
Estimate against measurement, compound 4: 1.1-fold (0.05 log units) below, within the range that was stated.
By their numbers in this assay, from the lowest: compounds 2, 1, 4 and 3 (each within the scatter of the next, the first and the last beyond it).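

Notes on the result: in this assay, the first step at the carbonyl carbon, 4-methoxyphenyl in place of 2-methoxyphenyl, gives a 1.9-fold lower number from compound 3 to compound 4 (0.28 log units; within the scatter), so with bromo held constant this pair cannot be told apart. With 4-methoxyphenyl held constant, bromo joins hydrogen and methoxy on the aromatic carbon, with a 1.2-fold higher number from compound 1 to compound 4 (0.07 log units; within the scatter) and a 1.3-fold higher number from compound 2 to compound 4 (0.11 log units; within the scatter), so the three compounds carrying this group form a flat set at that place, with no substituent separated from another. No supporting measurement is available that bears on these steps.

From the compounds shown here alone, only compound 3 and compound 4 cover the change at the carbonyl carbon, so it remains open whether the same small step would appear with hydrogen or methoxy in place of bromo on the aromatic carbon. Also open, going by these compounds, is whether an amine or a carboxylic acid on that aromatic carbon, or a longer alkoxy chain in place of the methoxy of 4-methoxyphenyl, would move the number beyond the scatter in this assay.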